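The compounds below may be only part of what the source reports. "The series", "measured", "known", "first", "only" and "open" are said of these compounds alone.

Measured in a functional assay on HEK293 cells for positive allosteric modulation of metabotropic glutamate receptor 5 (Rattus norvegicus), read by fluorescence and calcium flux; on this read-out higher numbers stand for larger maximal responses and lower numbers for smaller maximal responses:
compound 1 `C[C@@H](NC(=O)c1ccc(C#Cc2ccc(F)cc2F)cn1)C(C)(C)O` — 61.2%
compound 2 `C[C@@H](NC(=O)c1ccc(C#Cc2ncccc2F)cn1)C(C)(C)O` — 60.6%
compound 3 `C[C@H](NC(=O)c1ccc(C#Cc2cccc(F)c2)cn1)C(C)(C)C` — 70.8%

Compound 3 stands highest of the three numbers in this assay; compound 1 lies within the scatter of it, compound 2 beyond. Compound 4 `O=C(NCC1CC1)c1ccc(C#Cc2cccc(F)c2)cn1` differs from compound 3 by cyclopropylmethyl in place of 1,2,2-trimethylpropyl on an amide-type nitrogen. Among the measured compounds shown here, the one measured step, a number 0.6 percentage points lower from compound 1 to compound 2 (within the scatter), concerns the group on the triple-bonded carbon, not the amide-type nitrogen, so no measured step bears on this change. The series gives no direction for it; the expected step is none beyond the scatter, with a wide range to reflect the lack of comparable data. For compound 4 the estimate in this assay is 65%, ranging from 45% to 85%. The step thereby expected is a number 5.8 percentage points lower from compound 3 to compound 4 (within the scatter).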

Compound 4, largest response reached (reported as efficacy), in percent of the reference or control that the assay uses: 61.4%
Beside the measured number, compound 4's estimate is 3.6 percentage points above it, within the range that was stated.
By their numbers in this assay, from the lowest: compounds 2, 1, 4 and 3 (each within the scatter of the next, the first and the last beyond it).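

Among the compounds shown here, on the amide-type nitrogen, the first direct comparison in this assay is a number 9.4 percentage points lower from compound 3 to compound 4 (within the scatter), with cyclopropylmethyl in place of 1,2,2-trimethylpropyl. This position therefore accepts a three-membered ring and the loss of the defined stereocentre with the maximal response staying within the scatter. No supporting data offer an explanation for this step.

As far as these compounds go, an amine, a carboxylic acid or a longer chain on this nitrogen remains open. Also open, from the compounds shown here alone, is whether the same exchange gives a similar step with the 2,4-difluorophenyl group of compound 1 on the triple-bonded carbon.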